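Swapping a Nitro Group for Chlorine on a Sulfonamide Scaffold

A few compounds are considered here, and "the series" means these few. Any claim that something is new, unique, unknown or untested is made for them only; others in the source may bear on it.

Of the compounds shown here, two sharing one core have been measured in an ADME assay on HEK-293T cells (Homo sapiens) for inhibition, read by MTT assay, tested at 10 uM; on this read-out lower numbers stand for less inhibition and higher numbers for more inhibition at the one concentration tested (going by the name of the read-out). Compound 1, `CC1Cc2ccccc2N1S(=O)(=O)c1ccc(-c2cnc(C3CC3)o2)cc1`, gives 61.3% in this assay. Compound 2, `O=[N+]([O-])c1ccc2c(c1)N(S(=O)(=O)c1ccc(-c3cnc(C4CC4)o3)cc1)CC2`, gives 77.8%, the higher of the two numbers, and its gap to compound 1 lies beyond the usual scatter of such measurements. Going by the values given here, since the two compounds differ in more than one place, no single structural step can be drawn between them.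

Compound 3, `O=S(=O)(c1ccc(-c2cnc(C3CC3)o2)cc1)N1CCc2ccc(Cl)cc21`, has not yet been measured. It differs from compound 2 in one place: chloro in place of nitro on an aromatic carbon. Among the compounds with values here, only two numbers are known, and neither pair forms a single step. Within the data shown here, there is no measured example of this particular change to lean on.

With that in mind, the step expected in this assay is a number 9.8 percentage points lower from compound 2 to compound 3 (within the scatter), a modest move downward that may well stay within the usual scatter. For compound 3, the estimate in this assay is 68%, with a range from 50% to 84%.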

Compound 3, a percentage reported as inhibition, at one concentration (the size of the read-out at that concentration, not a potency): 71.9%
Beside the measured number, compound 3's estimate is 3.9 percentage points below it, and the stated range covers the measured number.
By their numbers in this assay, from the lowest: compound 1; then compounds 3 and 2 (each within the scatter of the next).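

In this assay, going by these compounds alone, replacing nitro with chloro gives a number 5.9 percentage points lower from compound 2 to compound 3 (within the scatter), the first step in this set that changes only one place. It shows that at this aromatic carbon, meta to a fused ring and para to a fused ring, the nitro group, with its hydrogen-bond acceptors, can give way to chloro, a single chlorine atom with none, without the read-out moving beyond the usual scatter. No measurement at hand speaks to the reason for this result.

From the compounds shown here alone, whether other groups at this same carbon would also stay within the scatter of compound 2 remains open, for example an amine, a methoxy group or a carboxylic acid. Also open, going by these compounds, is whether the same swap would behave alike on a core carrying other changes, such as that of compound 1, which differs from compound 2 in more than one place, and one step alone cannot establish a trend across the series.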